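Removing a hydroxyl: from compound 2 toward compound 4

This account rests on a few compounds, and the source may have more. Where it says the series, first, only, none or still open, it means among the compounds named here.

Measured so far:
compound 1 `COc1ccc(Cn2c(C(=O)O)c(CNCc3ccc(O)c(OC)c3)c3ccccc32)cc1`: > 50000 nM
compound 2 `COc1ccc(Cn2c(C(=O)O)c(CNCc3cc(OC)ccc3O)c3ccc(C)cc32)cc1`: > 50000 nM
compound 3 `COc1cccc(CNCc2c(C(=O)O)n(Cc3ccc(C)cc3)c3ccccc23)c1`: 21500 nM

In a functional assay on Bel-7402 cells (Homo sapiens) for antiproliferative activity, read by MTT assay, with a stated time of 72 h (on this read-out higher numbers stand for weaker inhibition and lower numbers for stronger inhibition), compound 2 gives > 50000 nM, which is a limit of the assay rather than a number. Compound 1 likewise gives only a limit, > 50000 nM. Among the compounds with values here, compound 3 is the one compound with a measured number, 21500 nM. Within the data shown here, two of the three results sit at the same boundary, (the limit of > 50000 nM in this assay, at which 2 of the 3 values shown sit), so compound 2 stands among the weaker entries, and no step between measured compounds can be counted here.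

Compound 4 `COc1ccc(Cn2c(C(=O)O)c(CN(C)Cc3cccc(OC)c3)c3ccc(C)cc32)cc1` differs from compound 2 in one place: (3-methoxybenzyl)(methyl)amino in place of (2-hydroxy-5-methoxybenzyl)amino on a saturated chain carbon bound to an aromatic carbon. Among the measured compounds shown here, the group that enters resembles the one carried by compound 3, whose value 21500 nM is a number rather than a limit. Accordingly, a step toward lower numbers in this assay is expected, modest in size, but with a real chance that only a limit is reported again.

Compound 4 is expected to give 25000 nM, within the range 8000 nM to 80000 nM. The step of an at least 2.0-fold lower number from compound 2 to compound 4 (0.30 log units; that floor lies within the scatter) is the estimated change.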

Compound 4, half-maximal inhibitory concentration: 33000 nM
For compound 4 the middle estimate is 1.3-fold (0.12 log units) below the measured one; low and high end bracket the measured number.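

In this assay, within the data shown here, the change on a saturated chain carbon bound to an aromatic carbon gives the first step that can be read at this position: an at least 1.5-fold lower number from compound 2 to compound 4 (0.18 log units; that floor lies within the scatter). This step is only a floor and not a full size, because compound 2 stands at a limit: the limit of > 50000 nM in this assay, at which 2 of the 4 values shown sit. That floor lies within the usual scatter, so the change is not shown to be a real gain, although the true step may be larger.

The change removes the hydroxyl and also puts a methyl on the nitrogen, and the compounds shown do not separate these two parts. They also leave open how (2-hydroxy-5-methoxybenzyl)(methyl)amino or a morpholine at this place would read in this assay.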